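Swapping the sulfonamide nitrogen substituent of compound 2

The source may report more compounds than this note shows. Statements on the series, on what has been measured and on what is new or still open speak of the compounds shown alone.

Among the measured compounds shown here, in a physicochemical assay for lipophilicity, at pH 7.4 (a lower number here means a more polar compound, a higher number a more lipophilic compound), three compounds on the shared core have numbers so far. Compound 2 (`CCS(=O)(=O)c1ccc(CN(CC(C)C)S(=O)(=O)c2ccc3c(c2)C(O)CC(C2CCOCC2)O3)nc1`) reads 1.42 and is the lowest of the three, beyond the scatter from both others. Compound 1 (`O=S(=O)(c1ccc2c(c1)C(O)CC(C1CCOCC1)O2)N1CCC(c2ccccc2)CC1`) reads 2.63 and compound 3 (`O=S(=O)(c1ccc2c(c1)C(O)CC(C1CCOCC1)O2)N1CCCC1c1ccccc1C(F)(F)F`) reads 3.41 in the same measurement.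

Compound 4 (`CC(C)CN(c1ccc(C#N)cc1)S(=O)(=O)c1ccc2c(c1)C(O)CC(C1CCOCC1)O2`) has not been measured. It carries 4-cyanophenyl in place of (5-(ethylsulfonyl)pyridin-2-yl)methyl on a sulfonamide nitrogen when set against compound 2. For the measured compounds named here, no two measured compounds differ in one place only, so no direct precedent exists for this change. Going by the values given here, compound 2 is the only measured compound with (5-(ethylsulfonyl)pyridin-2-yl)methyl and reads 1.42 as the lowest number, which gives the sole, weak ground for expecting a rise. The expected step is a number 1.48 log units higher from compound 2 to compound 4 (beyond the scatter) in the upward direction, beyond the scatter. Compound 4 is estimated at 2.9 (expected range 2.4 to 3.5).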

Compound 4, distribution coefficient: 3.07
Estimate against measurement, compound 4: 0.17 log units below, within the range that was stated.
By their numbers in this assay, from the lowest: compound 2; then compound 1; then compound 4; then compound 3.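

In this assay, among the compounds shown here, the change on a sulfonamide nitrogen from (5-(ethylsulfonyl)pyridin-2-yl)methyl to 4-cyanophenyl gives a number 1.65 log units higher from compound 2 to compound 4 (beyond the scatter) and is the first single-place comparison, showing that this position alone can carry a large step. The change is not a clean one: 12 heavy atoms and 3 hydrogen-bond acceptors leave, 8 heavy atoms and 1 hydrogen-bond acceptor enter, and the ring loses its hetero atom, so one step cannot assign the rise to any single feature. No measurement available here accounts for the step.

Which part of the exchange carries the step remains open. So does the reading of a plain phenyl or a carboxylic acid on this sulfonamide nitrogen.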